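Swapping Chlorines for Fluorines on a Weak Growth Inhibitor

The compounds below may be only part of what the source reports. "The series", "measured", "known", "first", "only" and "open" are said of these compounds alone.

Three measured compounds share one core and differ in the aryl group that sits on a carbonyl carbon. Compound 1 `COc1ccc(-c2cc(/C=C/C(=O)c3ccc(OC)c(OC)c3)[nH]n2)cc1` is the strongest of them: in a functional assay on HCT-116 cells (Homo sapiens) for inhibition, read by sulforhodamine B assay, with a stated time of 48 h (a higher number here means a weaker inhibitor of growth, a lower number a stronger inhibitor of growth), compound 1 gives 2480 nM. Compound 3 `COc1ccc(-c2cc(/C=C/C(=O)c3ccc(N)cc3)[nH]n2)cc1OC` gives 3510 nM in this assay. Compound 2 `COc1cc(-c2cc(/C=C/C(=O)c3ccc(Cl)c(Cl)c3)[nH]n2)cc(OC)c1OC` gives 21500 nM in this assay, the highest of the three numbers and so the weakest growth inhibition; its gap to compound 3 is the smaller one and its gap to compound 1 the larger one, and both lie beyond the usual scatter.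

Compound 4 `COc1cc(-c2cc(/C=C/C(=O)c3ccc(F)c(F)c3)[nH]n2)cc(OC)c1OC` has not yet been measured. It differs from compound 2 in one place: 3,4-difluorophenyl in place of 3,4-dichlorophenyl on a carbonyl carbon. Within the data shown here, no pair of measured compounds shows this same swap, so the size of the step has no direct precedent here, and the two other compounds carry quite different groups on that carbonyl carbon.

The expected step from compound 2 to compound 4 in this assay is a modest move toward a lower number, a 1.5-fold lower number from compound 2 to compound 4 (0.19 log units; within the scatter), of a size that may stay within the scatter. Compound 4 is therefore estimated to give about 14000 nM in this assay, with a plausible range from 5000 nM to 45000 nM.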

Compound 4, concentration for total growth inhibition: 13900 nM
Beside the measured number, compound 4's estimate is 1.0-fold (0.00 log units) above it; the range from low to high includes it.
By their numbers in this assay, from the lowest: compounds 1 and 3 (each within the scatter of the next); then compounds 4 and 2 (each within the scatter of the next).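

Among these compounds, this is the first step in the set in which only one place changes, and it isolates the group on the carbonyl carbon: with 3,4-difluorophenyl in place of 3,4-dichlorophenyl, this assay shows a 1.5-fold lower number from compound 2 to compound 4 (0.19 log units; within the scatter) and so does not separate these two groups. Both compounds share the core of compound 2, so within the scatter of the measurement, this exchange of one halogen pair for the other leaves the growth inhibition of that core unchanged. The data shown include no separate measurement that could explain why the step is so small.

Compounds 1 and 3 carry other groups at this position but differ from compound 2 elsewhere as well, so they cannot show how much of their distance from compound 2 comes from the group on the carbonyl carbon alone. Going by these compounds, what remains open is how the core of compound 2 would respond to a group of a different kind at this place, such as a carboxylic acid, a nitrile or a longer chain ending in an amine.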